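The source may hold more compounds than are shown below. What is called first, only, known or untested is meant among the compounds shown, and "the series" means these compounds.

Measured so far:
- compound 1, `COc1cccc(C2(O)SC=C(C)n3c2noc3=O)c1`: in a functional assay (Left cardiac atrium, Cavia porcellus), with a stated time of 30 min (a lower number here means that less compound is needed, a higher number that more compound is needed for the effect), compound 1 gives 490 nM
- compound 2, `CCOC1(c2cccc(OC)c2)SC=C(C)n2c1noc2=O`: compound 2 gives 38 nM
- compound 3, `COc1ccccc1C1(O)SC=C(C)n2c1noc2=O`: compound 3 gives 930 nM

Compound 4, `CCOC1(c2ccccc2OC)SC=C(C)n2c1noc2=O`, has not yet been measured in this assay. It comes from compound 3 by ethyl in place of hydrogen on an oxygen on a saturated carbon. Exactly the same change, at the same place, turns compound 1 into compound 2: ethyl in place of hydrogen on an oxygen on a saturated carbon. That measured step was a 13-fold lower number from compound 1 to compound 2 (1.11 log units; beyond the scatter). Compound 3 and compound 1 differ in their cores; how the two cores differ is not broken down here. The values of compound 3 and compound 1 lie within the scatter of each other, so the two starting points look alike. For compound 4 a step of about the same size is expected, a 13-fold lower number from compound 3 to compound 4 (1.11 log units; beyond the scatter), because the earlier step of a 13-fold lower number from compound 1 to compound 2 (1.11 log units; beyond the scatter) was large and well beyond the scatter. The estimate for compound 4 is therefore 72 nM, with a likely range from 25 nM to 220 nM.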

Compound 4, half-maximal effective concentration: 140 nM
Beside the measured number, compound 4's estimate is 1.9-fold (0.29 log units) below it; low and high end bracket the measured number.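

In this assay, putting ethoxy in place of hydroxy on the core of compound 3 gives a 6.6-fold lower number from compound 3 to compound 4 (0.82 log units; beyond the scatter), so the number falls here as well. Set beside the earlier step, the change carries over between the two cores in both direction and size: the same change on two cores in this assay, a 13-fold lower number (1.11 log units; beyond the scatter) from compound 1 to compound 2 and a 6.6-fold lower number (0.82 log units; beyond the scatter) from compound 3 to compound 4, 1.9-fold (0.29 log units) apart, within the scatter of two such steps. This shows agreement on these two pairs only; it does not show that the same step would appear on any other core, and it does not explain why the change lowers the number.

The compounds shown leave open how a longer chain such as propoxy would read on that oxygen. Going by these compounds, an amine in place of the hydroxy is equally open.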